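The source may report more compounds than this note shows. Statements on the series, on what has been measured and on what is new or still open speak of the compounds shown alone.

Measured so far in a functional assay on NCI-H23 cells (Homo sapiens) for cytotoxicity, read by sulforhodamine B assay, with a stated time of 48 h, tested at 1 uM; on this read-out higher numbers stand for a weaker effect at the one concentration tested and lower numbers for a stronger effect:

compound 1, `COc1ccc(-c2cc(/C=C/C(=O)c3ccc(N)cc3)[nH]n2)cc1`: 93%
compound 2, `COc1cc(-c2cc(/C=C/C(=O)c3ccc(N)cc3)[nH]n2)cc(OC)c1OC`: 95%
compound 3, `COc1ccc(C(=O)/C=C/c2cc(-c3cc(OC)c(OC)c(OC)c3)n[nH]2)cc1OC`: 93%

Compound 2 carries the top number of the three, but its gaps to compound 1 and to compound 3 both lie within the scatter, so the three sit together at the weak end of the read-out. Among the measured compounds shown here, the one step that is counted, a number 2 percentage points lower from compound 2 to compound 3 (within the scatter), concerns the aryl group on the carbonyl carbon, not the ring that is altered here, and it is itself within the scatter.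

Compound 4, `COc1ccc(-c2cc(/C=C/C(=O)c3ccc(N)cc3)[nH]n2)cc1OC`, differs from compound 2 as hydrogen in place of methoxy on an aromatic carbon. For the measured compounds named here, no measured step touches this position. Compound 1 and compound 2 differ in the number of methoxy groups on the same ring and give numbers within the scatter of each other, which is the only indirect hint available. On that basis no step beyond the scatter is expected, and the step from compound 2 to compound 4 is estimated as a number 1 percentage points lower from compound 2 to compound 4 (within the scatter). For compound 4 the expected value is 94%, within a range from 86% to 100%.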

Compound 4, a percentage reported as activity, at one concentration (the size of the read-out at that concentration, not a potency): 99%
The estimate for compound 4 lay 5 percentage points below the measured number, within the range that was stated.
By their numbers in this assay, from the lowest: compounds 1, 3, 2 and 4 (each within the scatter of the next).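

In this assay, among the compounds shown here, hydrogen in place of methoxy on this aromatic carbon, ortho to a methoxy group, gives a number 4 percentage points higher from compound 2 to compound 4 (within the scatter) and provides the first direct reading at this position. Methoxy in place of hydrogen on an aromatic carbon of the same ring gives a number 6 percentage points higher from compound 1 to compound 4 (within the scatter) and so leaves this read-out within the scatter as well, which means that neither change on this ring separates compound 4 from its neighbours at the one concentration tested. No supporting data bear on these two steps.

From the compounds shown here alone, it remains open whether a hydroxy group, an amine or a carboxylic acid on this aromatic carbon would give a step beyond the scatter. Also open, going by these compounds, is whether the same ring without any methoxy group would stay within the scatter of compound 4.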